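Urea series: swapping the stilbene arm for a biaryl

This account rests on a few compounds, and the source may have more. Where it says the series, first, only, none or still open, it means among the compounds named here.

Compound 1 `COC(=O)/C=C/c1cccc(N(Cc2ccc(/C=C/c3ccccc3F)cc2)C(=O)C2CCCCC2)c1` is the amide reference; in an assay on isolated protein with Bile acid receptor (Homo sapiens) as the target (on this read-out higher numbers stand for an effect only at larger amounts of compound and lower numbers for an effect already at smaller amounts), compound 1 gives 64 nM. Compound 2 `COC(=O)/C=C/c1cccc(N(Cc2ccc(/C=C/c3ccccc3F)cc2)C(=O)NC(C)C)c1` carries the urea instead, and in this assay compound 2 gives 431 nM. For the measured compounds named here, the only measured step so far, a 6.7-fold higher number from compound 1 to compound 2 (0.83 log units; beyond the scatter), is the change of isopropylamino in place of cyclohexyl on a carbonyl carbon. Compound 2 thus stands at the highest of the two numbers measured, with compound 1 the nearest at a lower number.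

Compound 3 `COC(=O)/C=C/c1cccc(N(Cc2ccc(-c3cccc(OC)c3)cc2)C(=O)NC(C)C)c1` keeps the urea of compound 2 and alters the far aryl arm: 3-methoxyphenyl in place of 2-(2-fluorophenyl)ethenyl on an aromatic carbon. The group leaves from an aromatic carbon of a six-membered aromatic ring of carbon only, para to a large group. Going by the values given here, no measured step touches this part of the molecule; the single step available concerns the carbonyl carbon and so does not bear on the new change. Among the compounds with values here, with no precedent, the expectation is only loosely founded. Compound 3 is estimated at 800 nM in this assay, with a range of 200 nM to 4000 nM, so that the expected step of a 1.9-fold higher number from compound 2 to compound 3 (0.27 log units; within the scatter) points to a weaker result but may well fall within the scatter.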

Compound 3, half-maximal effective concentration: 1370 nM
Estimate against measurement, compound 3: 1.7-fold (0.23 log units) below; the measured number falls inside the stated range.
By their numbers in this assay, from the lowest: compound 1; then compound 2; then compound 3.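

With the urea held constant, 3-methoxyphenyl in place of 2-(2-fluorophenyl)ethenyl on the aromatic carbon gives a 3.2-fold higher number from compound 2 to compound 3 (0.50 log units; beyond the scatter) in this assay, so this position, para to a large group, is a second place in the series where a single change moves the number beyond the scatter. The exchange removes the double bond outside aromatic rings and the fluorine and brings in an oxygen and one hydrogen-bond acceptor, and this single pair cannot separate which of these changes goes with the higher number. Nothing at hand explains the step.

Open, on these data alone, is whether the 3-methoxyphenyl arm gives a comparable step on the cyclohexyl amide of compound 1, which would show whether the arm and the carbonyl substituent act independently. Also open, as far as these compounds go, is how the number responds to other groups on this arm, such as a hydroxyl, an amine or a carboxylic acid in place of the methoxy, or a 2-fluorophenyl set directly on the aromatic carbon without the ethenyl link.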